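The compounds below may be only part of what the source reports. "The series", "measured", "known", "first", "only" and "open" are said of these compounds alone.

Measured in an ADME assay on SH-SY5Y cells (Homo sapiens) for cytotoxicity, read by MTT assay, with a stated time of 72 h; a higher number here means a weaker inhibitor, a lower number a stronger inhibitor:
- compound 1 `O=C(CN1CCN(C(=O)c2ccccc2)CC1)N1CCN(CCCc2c[nH]c3ccccc23)CC1`: > 200000 nM, which is a limit of the assay
- compound 2 `O=C(CN1CCN(C(=O)c2ccc(F)cc2)CC1)N1CCN(CCCc2c[nH]c3ccccc23)CC1`: 188000 nM
- compound 3 `O=C(CN1CCN(C(=O)c2cccc(Cl)c2)CC1)N1CCN(CCCc2c[nH]c3ccccc23)CC1`: 120000 nM

Compound 2 at 188000 nM lies within the scatter of compound 3, as the measured step shows: a 1.6-fold lower number from compound 2 to compound 3 (0.19 log units; within the scatter). The third member of the set, compound 1, has only a limit as its result.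

Compound 4 `COc1ccc2[nH]cc(CCCN3CCN(C(=O)CN4CCN(C(=O)c5ccc(F)cc5)CC4)CC3)c2c1` has methoxy in place of hydrogen on an aromatic carbon. Within the data shown here, no measured step covers this place, so the evidence is indirect. The three measured steps all change the other end of the molecule: an at least 1.0-fold lower number from compound 1 to compound 2 (0.02 log units; that floor lies within the scatter), an at least 1.6-fold lower number from compound 1 to compound 3 (0.22 log units; that floor lies within the scatter) and a 1.6-fold lower number from compound 2 to compound 3 (0.19 log units; within the scatter). All three stay within the scatter, so they give a weak precedent for a small effect in this assay, and no direction can be drawn from them.

No step beyond the scatter is expected, and the expected change is a 1.3-fold lower number from compound 2 to compound 4 (0.10 log units; within the scatter). The estimated value for compound 4 is 150000 nM, with an expected range of 75000 nM to 200000 nM.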

Compound 4, half-maximal inhibitory concentration: > 200000 nM
Compound 4 gave a limit, no number; the forecaster's own chance of this, stated with the estimate: 25%; middle value at least 1.3-fold (0.12 log units) away from the limit.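

In this assay compound 4 gives > 200000 nM, which is a limit and not a number. Among these compounds, this is the first reading at the indole end of the series, and the change from 1H-indol-3-yl to 5-methoxy-1H-indol-3-yl gives an at least 1.0-fold higher number from compound 2 to compound 4 (0.02 log units; that floor lies within the scatter), so the true size of the step remains unknown. Limits now appear with changes at both ends of the molecule, and this position yields a bound rather than a measured size: the limit of > 200000 nM in this assay, at which 2 of the 4 values shown sit.

As far as these compounds go, the direction and size of any methoxy effect at this position remain open. Also open, from the compounds shown here alone, is whether an amine, a carboxylic acid or a longer alkoxy chain on this aromatic carbon would give a measurable number in this assay, and whether methoxy would behave the same way alongside the 3-chlorophenyl group of compound 3.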